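Trimming the sulfonyl substituent down to methyl

The source may report more compounds than this note shows. Statements on the series, on what has been measured and on what is new or still open speak of the compounds shown alone.

Compound 2 `CC(C)(C)S(=O)(=O)NC(=O)c1ccc(N2CCN(Cc3ccccc3-c3ccc(Cl)cc3)CC2)cc1` is known only through a limit: in an assay on isolated protein for inhibition of Apoptosis regulator Bcl-2/Bcl-2 homologous antagonist/killer (Homo sapiens), read by surface plasmon resonance, with a stated time of 1 h (a lower number here means that less compound is needed, a higher number that more compound is needed for the effect), compound 2 gives > 16000 nM. Compound 1 `CC1(C)C2CC[C@]1(CS(=O)(=O)NC(=O)c1ccc(N3CCN(Cc4ccccc4-c4ccc(Cl)cc4)CC3)cc1)C(=O)C2` gives 1020 nM in this assay, and the step of an at least 15-fold higher number from compound 1 to compound 2 (1.19 log units; beyond the scatter) replaced the bicyclic group with tert-butyl; the resulting value sits at the limit of > 16000 nM in this assay, at which 1 of the 2 values shown sits. Compound 3 `CS(=O)(=O)NC(=O)c1ccc(N2CCN(Cc3ccccc3-c3ccc(Cl)cc3)CC2)cc1` takes the same direction further: methyl in place of tert-butyl on a sulfonyl sulfur. Within the data shown here, the one measured step ran toward weaker binding, so compound 3 is expected to show no recovery, with an expected step that the limit leaves unreadable from compound 2 to compound 3. The estimate for compound 3 is 30000 nM, between 12000 nM and 100000 nM, most probably reported again only as a limit.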

Compound 3, half-maximal effective concentration: 8620 nM
Beside the measured number, compound 3's estimate is 3.5-fold (0.54 log units) above it; measured number below the stated range.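

Compound 2 remains only a limit, so its comparison with methyl is fixed on one side alone: the limit of > 16000 nM in this assay, at which 1 of the 3 values shown sits. Against that limit, the step runs an at least 1.8-fold lower number from compound 2 to compound 3 (0.26 log units; that floor lies within the scatter), so methyl on the sulfonyl sulfur loses nothing measurable against tert-butyl. Removing the bicyclic group altogether gives an 8.5-fold higher number from compound 1 to compound 3 (0.93 log units; beyond the scatter), so in these compounds the clear advantage belongs to that group, not to tert-butyl.

As far as these compounds go, whether it rests on the carbonyl or on the carbon frame of the bicyclic group stays open. So does what a cyclohexyl group, a phenyl group or an amine-bearing chain would give on the sulfonyl sulfur.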